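The compounds below may be only part of what the source reports. "The series", "measured", "known", "first", "only" and "open" are said of these compounds alone.

Compound 1 `O=C(Nc1cc(-c2nc3ccccc3s2)ccc1Cl)c1cc([N+](=O)[O-])ccc1Cl` is the starting point. In an ADME assay on BJ cells (Homo sapiens) for cytotoxicity, with a stated time of 72 h (a lower number here means that less compound is needed, a higher number that more compound is needed for the effect), compound 1 gives > 25000 nM, which is a limit of the assay and not a measured number. Compound 2 `Cc1ccc(-c2nc3ccccc3o2)cc1NC(=O)c1cc([N+](=O)[O-])ccc1Cl` gives > 14000 nM, also a limit. Compound 3 `O=C(Nc1cc(-c2nc3ccccc3o2)ccc1F)c1cc([N+](=O)[O-])ccc1Cl` gives > 25000 nM, again a limit. Among the measured compounds shown here, the step that the two limits leave unreadable from compound 2 to compound 3 has no readable size, so no measured step bears on the change to compound 4 `COc1ccc(-c2nc3ccccc3s2)cc1NC(=O)c1cc([N+](=O)[O-])ccc1Cl`, which is methoxy in place of chloro on an aromatic carbon. All three measured values sit at limits, as the limit of > 14000 nM in this assay, at which 1 of the 3 values shown sits, and the limit of > 25000 nM in this assay, at which 2 of the 3 values shown sit, show, and nothing among them points to a readable step in either direction. Compound 4 is therefore expected to give 30000 nM, within 10000 nM and 100000 nM. The expected step that the limit leaves unreadable from compound 1 to compound 4 is thus no step beyond the scatter.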

Compound 4, half-maximal effective concentration: > 25000 nM
Compound 4: a limit, no number (the forecaster's own chance of this, stated with the estimate: 80%); the middle value does not contradict the limit.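

Among the compounds shown here, compound 1 and compound 4 both give only a limit in this assay, and no step between them can be read. The compounds shown leave open at what concentration, if any, each would reach the half-maximal effect.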